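This account rests on a few compounds, and the source may have more. Where it says the series, first, only, none or still open, it means among the compounds named here.

Compound 1 `O=C(Nc1ccc(O)cc1)c1ncc(-c2ccc(F)cc2)o1`: > 30000 nM
Compound 2 `O=C(Nc1ccc(O)cc1)c1ncc(-c2ccccc2)o1`: 1270 nM

Among the measured compounds shown here, in a functional assay on HepG2 cells (Homo sapiens) for cytotoxicity, read by CCK-8 assay (on this read-out lower numbers stand for stronger inhibition and higher numbers for weaker inhibition), compound 2 gives 1270 nM, the only actual number so far. For compound 1, > 30000 nM is a limit of the assay and not a number. Compound 3 `CCN(CC)c1ccc(NC(=O)c2ncc(-c3ccccc3)o2)cc1` keeps the core of compound 2 and carries diethylamino in place of hydroxy on an aromatic carbon, para to a large group: diethylamino in place of hydroxy on an aromatic carbon. For the measured compounds named here, only one measured step exists, and it lies elsewhere in the molecule, so it bears on this change only indirectly. It also rests on (the limit of > 30000 nM in this assay, at which 1 of the 2 values shown sits). Since an at least 23-fold lower number from compound 1 to compound 2 (1.37 log units; beyond the scatter) shows that one change can move the number far, a wide range is expected, though no direction can be read from it. The expected result in this assay is a 1.2-fold higher number from compound 2 to compound 3 (0.07 log units; within the scatter), with no clear shift beyond the scatter. Compound 3 is estimated at 1500 nM, with an expected range from 250 nM to 10000 nM.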

Compound 3, half-maximal inhibitory concentration: > 30000 nM
Compound 3 was reported as a limit; the forecaster's own chance of this, stated with the estimate: 15%; middle value at least 20-fold (1.30 log units) away from the limit.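

In this assay, replacing hydroxy with diethylamino gives an at least 23-fold higher number from compound 2 to compound 3 (1.37 log units; beyond the scatter). Among the compounds shown here, the only earlier step lay elsewhere in the molecule, so this is the first sign that the aromatic position para to a large group also responds strongly to a single change, here towards a higher number. Compound 3 gives > 30000 nM, which is a limit of the assay and not a number.

As far as these compounds go, how far this step really reaches stays open, as it is bounded from one side only: the limit of > 30000 nM in this assay, at which 2 of the 3 values shown sit. The compounds shown also leave open whether a methoxy group or a primary amine at this position would stay close to compound 2 or would likewise reach the limit.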